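The compounds below may be only part of what the source reports. "The series", "measured", "known", "first", "only" and "open" are said of these compounds alone.

For the measured compounds named here, in a functional assay on MCF7 cells (Homo sapiens) for inhibition, read by radiometric assay and XTT assay (a lower number here means a stronger inhibitor, a higher number a weaker inhibitor), compound 1 `CCCCCC[C@@]1(C)SC(=O)C=C1OCCCCCl` gives 20.8 ug/mL and compound 2 `C=CCOC1=CC(=O)S[C@]1(C)CCCCCC` gives 9 ug/mL as the lower of the two numbers so far. Going by the values given here, the one measured step is a 2.3-fold lower number from compound 1 to compound 2 (0.36 log units; beyond the scatter) and is modest, with vinyl in place of 3-chloropropyl on a saturated chain carbon bound to an oxygen on an unsaturated carbon.

Compound 3 `C#CCOC1=CC(=O)S[C@]1(C)CCCCCC` comes next and carries ethynyl in place of vinyl at that same place, or allyloxy to propargyloxy when cut one bond further out, and the counted difference reads ethynyl in place of vinyl on a saturated chain carbon bound to an oxygen on an unsaturated carbon as the whole change. Among the compounds with values here, no measured step covers this exact exchange, so the guide is rough. The earlier step replaced 3-chloropropyl, whereas this change trades a double bond for a triple bond. Within the data shown here, with compound 2 at 9 ug/mL as the anchor and a 2.3-fold lower number from compound 1 to compound 2 (0.36 log units; beyond the scatter) as the only guide, a smaller move is expected in this assay with no direction favoured, and none beyond the scatter. The estimated step is a 1.1-fold lower number from compound 2 to compound 3 (0.05 log units; within the scatter) and is expected to stay within the scatter. Compound 3 is expected at 8 ug/mL with an estimated range from 3.5 ug/mL to 18 ug/mL in this read-out.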

Compound 3, half-maximal inhibitory concentration: 8.9 ug/mL
Beside the measured number, compound 3's estimate is 1.1-fold (0.05 log units) below it, and the stated range covers the measured number.
By their numbers in this assay, from the lowest: compounds 3 and 2 (each within the scatter of the next); then compound 1.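

In this assay, the exchange of vinyl for ethynyl on a saturated chain carbon bound to an oxygen on an unsaturated carbon gives a 1.0-fold lower number from compound 2 to compound 3 (0.00 log units; within the scatter), so the double bond and the triple bond in this group read alike at this place. The move away from 3-chloropropyl now stands on two steps, a 2.3-fold lower number from compound 1 to compound 2 (0.36 log units; beyond the scatter) and a 2.3-fold lower number from compound 1 to compound 3 (0.37 log units; beyond the scatter), which shows that the earlier shift is not tied to vinyl alone and is shared by both short unsaturated groups among these three compounds. Nothing on hand gives a measured property that could account for either the flat step or the two larger ones.

The compounds shown leave open whether the step from 3-chloropropyl follows its chlorine or its chain length, a question that a plain propyl group or a 3-hydroxypropyl group at the same place would address. Also open, as far as these compounds go, is how a benzyl group or a chain ending in an amine would read at this place, and whether the flat exchange of vinyl for ethynyl would hold with a shorter chain elsewhere on the shared core.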